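Swapping a pyridine for a methyl-oxazole on the core

The source may hold more compounds than are shown below. What is called first, only, known or untested is meant among the compounds shown, and "the series" means these compounds.

Compound 1, `Cn1ccc(-c2cccc3c2CCC3c2ncc[nH]2)n1`, gives 19% in a functional assay on CHO cells for agonist activity at Alpha-1A adrenergic receptor (Homo sapiens), read by FLIPR and calcium flux; a lower number here means a smaller maximal response, a higher number a larger maximal response.
Compound 2, `Cn1nccc1-c1cccc2c1CCC2c1ncc[nH]1`, gives 58% in this assay.
Compound 3, `c1cncc(-c2cccc3c2CCC3c2ncc[nH]2)c1`, gives 36% in this assay.

Compound 3 stands second highest of the three: it sits a number 17 percentage points higher from compound 1 to compound 3 (beyond the scatter) and a number 22 percentage points lower from compound 2 to compound 3 (beyond the scatter). Compound 4, `Cc1oncc1-c1cccc2c1CCC2c1ncc[nH]1`, is not yet measured. It differs from compound 3 in one place: 5-methyl-1,2-oxazol-4-yl in place of pyridin-3-yl on an aromatic carbon. Among the compounds with values here, two measured steps bear on this exchange of one aromatic group on the same carbon of the shared core. The step of a number 39 percentage points higher from compound 1 to compound 2 (beyond the scatter) shows that a five-membered ring bearing a methyl can give a large rise, while a number 22 percentage points lower from compound 2 to compound 3 (beyond the scatter) shows that a six-membered ring with one hetero atom sat in between. Within the data shown here, the entering 5-methyl-1,2-oxazol-4-yl is again a five-membered ring bearing a methyl, so a modest rise in this assay is expected, with wide uncertainty, since no measured compound carries this group. For compound 4 the expected step is a number 12 percentage points higher from compound 3 to compound 4 (beyond the scatter), giving an estimated 48%, between 28% and 68%.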

Compound 4, largest response reached (Emax), in percent of the reference or control that the assay uses: 63%
The estimate for compound 4 lay 15 percentage points below the measured number; the range from low to high includes it.
By their numbers in this assay, from the lowest: compound 1; then compound 3; then compounds 2 and 4 (each within the scatter of the next).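

In this assay, the step of a number 27 percentage points higher from compound 3 to compound 4 (beyond the scatter) shows that 5-methyl-1,2-oxazol-4-yl on this aromatic carbon can do better than pyridin-3-yl, even though both groups have the same count of heavy atoms. The step of a number 5 percentage points higher from compound 2 to compound 4 (within the scatter) puts the new group level with 1-methyl-1H-pyrazol-5-yl, whereas a number 44 percentage points higher from compound 1 to compound 4 (beyond the scatter) shows that a methyl-bearing five-membered ring is not enough by itself, with compound 1 going against any such pattern. No available evidence explains these differences between the groups.

The compounds shown leave open whether the methyl on the 1,2-oxazole ring matters, as the unmethylated 1,2-oxazol-4-yl group is not among them. They also leave open how a plain phenyl ring, an aminomethyl group or a carboxylic acid would behave on this carbon.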